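This account rests on a few compounds, and the source may have more. Where it says the series, first, only, none or still open, it means among the compounds named here.

The measured compounds and their values in a functional assay on T47D cells (Homo sapiens) for inhibition; a higher number here means a weaker inhibitor, a lower number a stronger inhibitor:

Compound 1, `Oc1ccccc1-c1cc(-c2ccccc2C(F)(F)F)cc(-c2ccccc2O)n1`, gives 22500 nM.
Compound 3, `Oc1ccccc1-c1cc(-c2ccccc2OC(F)(F)F)cc(-c2ccccc2O)n1`, gives 1730 nM.
Compound 2, `Oc1ccccc1-c1cc(-c2cccc(C(F)(F)F)c2)cc(-c2ccccc2O)n1`, gives only a limit of the assay, > 50000 nM; it is one of the values sitting at the limit of > 50000 nM in this assay, at which 1 of the 3 values shown sits.

Compound 3 differs from compound 1 by one change, (trifluoromethoxy in place of trifluoromethyl on an aromatic carbon). That change made a large step: a 13-fold lower number from compound 1 to compound 3 (1.11 log units; beyond the scatter).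

Compound 2 and compound 4 share a core that differs from the core of compound 1 and compound 3 as 3-(trifluoromethyl)phenyl in place of 2-(trifluoromethyl)phenyl on an aromatic carbon. This change carried compound 1 to the limit of the assay: an at least 2.2-fold higher number from compound 1 to compound 2 (0.34 log units; beyond the scatter).

Compound 4, `Oc1ccccc1-c1cc(-c2cccc(OC(F)(F)F)c2)cc(-c2ccccc2O)n1`, is not yet measured. It differs from compound 2 by trifluoromethoxy in place of trifluoromethyl on an aromatic carbon. Going by the values given here, this is the same kind of change as the one from compound 1 to compound 3, not the same change: there the trifluoromethoxy enters ortho to a large group, here it enters meta to a large group.

Because a 13-fold lower number from compound 1 to compound 3 (1.11 log units; beyond the scatter) was large, a step of similar direction is expected here, though the starting point is only a limit and the surroundings of the place differ, so the expectation is less firm. The step expected into compound 4 in this assay is an at least 5.5-fold lower number from compound 2 to compound 4 (0.74 log units; beyond the scatter). Compound 4 is therefore estimated at 9000 nM, expected to fall between 2500 nM and 50000 nM.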

Compound 4, half-maximal inhibitory concentration: > 50000 nM
Compound 4: a limit, no number; the forecaster's own chance of this, stated with the estimate: 35%; middle value at least 5.5-fold (0.74 log units) away from the limit.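

In this assay compound 4 gives only a limit of the assay, > 50000 nM. Compound 2 stands at that same limit, so no step from compound 2 to compound 4 can be read: the limit of > 50000 nM in this assay, at which 2 of the 4 values shown sit.

The compounds shown leave open how far each of the two lies past the limit, and so whether trifluoromethoxy in place of trifluoromethyl changes the number at all at this place.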